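The source may report more compounds than this note shows. Statements on the series, on what has been measured and on what is new or still open speak of the compounds shown alone.

In a toxicity assay on KB cells (Homo sapiens) for cytotoxicity, read by fluorescence, with a stated time of 3 days (a lower number here means that less compound is needed, a higher number that more compound is needed for the effect), compound 2 (`CCCCOC(=O)CNC(=O)[C@H](CSc1ccc([N+](=O)[O-])cc1[N+](=O)[O-])NC(=O)CC[C@H](NC(=O)CC(C)(C)C)C(=O)OCCCC`) gives 250 uM, the higher of the two numbers measured, while compound 1 (`CCCCOC(=O)CNC(=O)[C@H](CSc1ccc([N+](=O)[O-])cc1[N+](=O)[O-])NC(=O)CC[C@H](NC(=O)OCc1ccccc1)C(=O)OCCCC`) gives 95.2 uM. Compound 3 (`CCCCOC(=O)CNC(=O)[C@H](CSc1ccc([N+](=O)[O-])cc1[N+](=O)[O-])NC(=O)CC[C@H](Nc1nc(N)nc(Cl)n1)C(=O)OCCCC`) differs from compound 2 as follows: 4-amino-6-chloro-1,3,5-triazin-2-yl in place of neopentylcarbonyl on an amine nitrogen. Within the data shown here, the only measured step, a 2.6-fold higher number from compound 1 to compound 2 (0.42 log units; beyond the scatter), also changed the group at this amine nitrogen. Neither measured compound carries the entering group, so that step is only a loose guide. With compound 2 at the top of the measured range, a modest move to a lower number in this assay is expected, an estimated 2.1-fold lower number from compound 2 to compound 3 (0.32 log units; beyond the scatter). For compound 3 the expected value is 120 uM, within an estimated range of 40 uM to 300 uM.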

Compound 3, concentration for half-maximal effect: > 300 uM
Compound 3 ended at the assay's limit (the forecaster's own chance of this, stated with the estimate: 15%); at least 2.5-fold (0.39 log units) between middle value and limit.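

In this assay compound 3 stands at a limit of the assay, not at a number: the limit of > 300 uM in this assay, at which 1 of the 3 values shown sits.

At this amine nitrogen, 4-amino-6-chloro-1,3,5-triazin-2-yl therefore brings no move to a lower number, and against benzyloxycarbonyl the change gives an at least 3.1-fold higher number from compound 1 to compound 3 (0.49 log units; beyond the scatter). Against neopentylcarbonyl the reading is only an at least 1.2-fold higher number from compound 2 to compound 3 (0.07 log units; that floor lies within the scatter), so these two groups cannot be put in order.

Going by these compounds, the true value of compound 3 stays open. So does what a free amine or an acetyl group on this amine nitrogen would give in this assay.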